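The source may hold more compounds than are shown below. What is called first, only, known or untested is meant among the compounds shown, and "the series" means these compounds.

Measured in an ADME assay on the whole organism (strain 129/SvEvBrd x C57BL/6) for metabolic stability, with Mus musculus as the target; a higher number here means that the compound lasts longer, a lower number that the compound disappears faster:
compound 1 `CC(=O)c1cccc([C@@H](O)[C@H](O)[C@H](O)CO)n1`: 2.1 h
compound 2 `CCc1[nH]c(C(C)=O)nc1[C@@H](O)[C@H](O)[C@H](O)CO`: 2.8 h
compound 3 `CC(O)c1nc([C@@H](O)[C@H](O)[C@H](O)CO)c[nH]1`: 4.4 h

Compound 1 gives 2.1 h and compound 3 gives 4.4 h. The gap between these two values lies outside the usual scatter, with compound 3 the higher. Compound 2 gives 2.8 h. The gap between compound 2 and compound 3 lies within the scatter of repeated measurements. These two compounds cannot be told apart.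

The next compound is compound 4 `CN(C)C(=O)c1nc([C@@H](O)[C@H](O)[C@H](O)CO)c[nH]1`. It has dimethylcarbamoyl in place of 1-hydroxyethyl on an aromatic carbon.

Among the measured compounds shown here, no pair of measured compounds differs in just one place, so nothing here shows directly how large a single change tends to be in this assay. For the measured compounds named here, the only guide is the spread of the three values, which run from compound 1 at 2.1 h to compound 3 at 4.4 h. Even with their structures differing in more than one place, these values stay close together, so a large jump seems unlikely.

The expected change, a 1.5-fold lower number from compound 3 to compound 4 (0.17 log units; within the scatter), is a modest fall that stays within the scatter. For compound 4 the estimated half-life is 3 h, with an expected range from 1.2 h to 7 h.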

Compound 4, half-life: 4 h
For compound 4 the middle estimate is 1.3-fold (0.12 log units) below the measured one; measured number inside the range.
By their numbers in this assay, from the lowest: compounds 1, 2, 4 and 3 (each within the scatter of the next, the first and the last beyond it).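

In this assay, among the compounds shown here, the step of a 1.1-fold lower number from compound 3 to compound 4 (0.04 log units; within the scatter) is the first comparison of two compounds that differ in one place, so it gives a first direct reading at this aromatic carbon, between two ring nitrogen atoms. Here, 1-hydroxyethyl, with 3 heavy atoms and 1 hydrogen-bond donor, gives way to dimethylcarbamoyl, with 5 heavy atoms and 0 hydrogen-bond donors, yet compound 3 and compound 4 cannot be told apart by half-life. No measurement shown here offers an explanation for this result.

This single pair leaves open whether other groups at this position, such as an amine, a carboxylic acid or a longer chain, would also leave the half-life within the scatter of compound 3. It also leaves open whether the same exchange would behave in the same way on the cores of compound 1 and compound 2, which do not yet have a one-place partner among the compounds shown.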